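A few compounds are considered here, and "the series" means these few. Any claim that something is new, unique, unknown or untested is made for them only; others in the source may bear on it.

Compound 1 `OC1CCN(c2ccc(-c3cc(Cl)ccc3Cl)nn2)CC1`, compound 2 `OC1CCN(c2ccc(-c3cccc(Cl)c3)nn2)CC1` and compound 3 `Cc1ccccc1-c1ccc(N2CCC(O)CC2)nn1` share one core and differ only in the groups attached to a six-membered aromatic ring of carbon only. In a functional assay on the whole organism with Mus musculus as the target, in the maximal electroshock model (a higher number here means that more compound is needed for the effect, a lower number that less compound is needed), compound 1 gives 30 mg/kg, compound 2 gives 45 mg/kg and compound 3 gives 30 mg/kg, all within the scatter of one another. Compound 4 `Cc1cc(Cl)ccc1-c1ccc(N2CCC(O)CC2)nn1` has not yet been measured. It arises from compound 3 by chloro in place of hydrogen on an aromatic carbon, the same kind of change as from compound 2 to compound 1, (chloro in place of hydrogen on an aromatic carbon), which produced a 1.5-fold lower number from compound 2 to compound 1 (0.18 log units; within the scatter). The surroundings differ: in compound 1 the chloro sits ortho to a large group and para to a chloro group, whereas in compound 4 it sits meta to a methyl group and para to a large group. How the core of compound 3 differs from that of compound 2 is not broken down here. Because the earlier change gave a 1.5-fold lower number from compound 2 to compound 1 (0.18 log units; within the scatter), a similarly small step is expected here, a 1.2-fold lower number from compound 3 to compound 4 (0.08 log units; within the scatter). Compound 4 is therefore estimated at 25 mg/kg, with a likely range from 12 mg/kg to 50 mg/kg.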

Compound 4, dose for half-maximal effect: 10 mg/kg
The estimate for compound 4 lay 2.5-fold (0.40 log units) above the measured number; measured number outside the range, below it.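

In this assay, chloro in place of hydrogen on an aromatic carbon gives a 3.0-fold lower number from compound 3 to compound 4 (0.48 log units; beyond the scatter). Carried from one core to the other, the change shows no difference in size that can be told from scatter: the same change on two cores in this assay, a 1.5-fold lower number (0.18 log units; within the scatter) from compound 2 to compound 1 and a 3.0-fold lower number (0.48 log units; beyond the scatter) from compound 3 to compound 4, 2.0-fold (0.30 log units) apart, within the scatter of two such steps This does not fix a size for the change: there are only two pairs, only the newer step lies beyond the scatter, and the chloro has different surroundings in each.

The compounds shown leave open whether fluoro, methoxy or an amine in the same place would lower the number as chloro does in compound 4. Going by these compounds, whether the step would hold on further cores also remains open.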